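The source may hold more compounds than are shown below. What is called first, only, known or untested is meant among the compounds shown, and "the series" means these compounds.

Measured in a functional assay on M21 cells (Homo sapiens) for antiproliferative activity, read by sulforhodamine B assay, with a stated time of 48 h; on this read-out higher numbers stand for weaker inhibition and lower numbers for stronger inhibition:
- compound 1 `Cc1ccc(NS(=O)(=O)c2ccc(N3CCNC3=O)cc2)cc1`: 260 nM
- compound 2 `O=C1NCCN1c1ccc(S(=O)(=O)Nc2ccc(F)cc2)cc1`: 230 nM
- compound 3 `Cc1ccc(NS(=O)(=O)c2ccc(N3CCNC3=O)cc2)cc1C`: 94 nM

Compound 3 has the lowest number of the three, and its steps to both other compounds lie beyond the scatter. Compound 4 `O=C1NCCN1c1ccc(S(=O)(=O)Nc2ccc(I)cc2)cc1` is not yet measured. It carries 4-iodophenyl in place of 3,4-dimethylphenyl on a sulfonamide nitrogen.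

The closest measured comparison is a 2.4-fold lower number from compound 2 to compound 3 (0.39 log units; beyond the scatter), which sets 4-fluorophenyl against the same 3,4-dimethylphenyl. The step of a 2.8-fold lower number from compound 1 to compound 3 (0.44 log units; beyond the scatter) is of similar size and shows the gain that came with adding one methyl to compound 1. The step of a 1.1-fold lower number from compound 1 to compound 2 (0.05 log units; within the scatter) shows that fluoro and methyl on that aromatic carbon cannot be told apart in this series. Among the measured compounds shown here, no iodo compound has been measured, so this reading carries over from fluoro and methyl only and remains uncertain.

Compound 4 has a single group on its phenyl, like compound 1 and compound 2, so a modest loss relative to compound 3 is the likeliest outcome. The expected move is a 2.0-fold higher number from compound 3 to compound 4 (0.31 log units; beyond the scatter), towards a higher number in this assay. Compound 4 is estimated at 190 nM, with an expected range of 75 nM to 450 nM.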

Compound 4, half-maximal inhibitory concentration: 260 nM
Estimate against measurement, compound 4: 1.4-fold (0.14 log units) below; the range from low to high includes it.
By their numbers in this assay, from the lowest: compound 3; then compounds 2, 1 and 4 (each within the scatter of the next).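

In this assay, iodo on this aromatic carbon cannot be told apart from fluoro, a 1.1-fold higher number from compound 2 to compound 4 (0.05 log units; within the scatter), or from methyl, no change at the digits printed from compound 1 to compound 4 (within the scatter), so three quite different single groups on the phenyl now give the same reading within the scatter. The replacement of 3,4-dimethylphenyl on the sulfonamide nitrogen by 4-iodophenyl gives a 2.8-fold higher number from compound 3 to compound 4 (0.44 log units; beyond the scatter), which leaves compound 3 apart from all three compounds with a single group on the phenyl, and none of the four compounds goes against this split. No measured property at hand bears on why the three single groups read alike or why compound 3 stands apart.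

The compounds shown leave open whether the lower number of compound 3 depends on the two methyl groups as such or would follow from any two groups on the phenyl, a question that a dichlorophenyl or a methyl paired with a chloro group could address. They also leave open whether the level reading holds for a phenyl carrying an amine or a carboxylic acid, since only methyl and halogen groups appear here.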